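The compounds below may be only part of what the source reports. "The series", "measured", "known", "first", "only" and "open" are said of these compounds alone.

Measured so far in a functional assay on LOX IMVI cells (Homo sapiens) for inhibition, read by sulforhodamine B assay, with a stated time of 48 h; on this read-out lower numbers stand for stronger inhibition of growth and higher numbers for weaker inhibition of growth:
compound 1 `Nc1cc(N)c2nc(-c3ccccc3)c(Oc3ccc(Cl)c(Cl)c3)nc2c1` gives 33900 nM;
compound 2 `CCOC(=O)[C@H](CCC(=O)O)NC(=O)c1ccc(Sc2nc3cc(N)cc(N)c3nc2-c2ccccc2)cc1` gives 8510 nM;
compound 3 `CCOC(=O)[C@H](CCC(=O)O)NC(=O)c1ccc(CNc2nc3cc(N)cc(N)c3nc2-c2ccccc2)cc1` gives < 100000 nM, which is a limit of the assay and not a number (the limit of < 100000 nM in this assay, at which 1 of the 3 values shown sits).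

Compound 1 carries the highest of the two numbers in this assay; compound 2 sits at a lower number, beyond the scatter. Compound 4 `COc1ccc(Sc2nc3cc(N)cc(N)c3nc2-c2ccccc2)cc1` has not been measured. Its change from compound 1 is (4-methoxyphenyl)sulfanyl in place of 3,4-dichlorophenoxy on an aromatic carbon. Among the compounds with values here, no step between measured compounds has been counted. Compound 2, the other thioether, lies below compound 1, so a modest move to stronger inhibition is expected, roughly a 2.3-fold lower number from compound 1 to compound 4 (0.35 log units; beyond the scatter). For compound 4 the estimate is 15000 nM, with a range from 4000 nM to 60000 nM.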

Compound 4, concentration for total growth inhibition: < 100000 nM
Compound 4 gave a limit, no number; the forecaster's own chance of this, stated with the estimate: 10%; the middle value does not contradict the limit.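

Compound 4 gives < 100000 nM, which is a limit and not a number, so no step from compound 1 to compound 4 can be read: the limit of < 100000 nM in this assay, at which 2 of the 4 values shown sit.

Going by these compounds, whether (4-methoxyphenyl)sulfanyl in place of 3,4-dichlorophenoxy strengthens or weakens inhibition of growth in this assay stays open.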